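Long-chain amides: furanoyl to dienoyl exchange

The compounds below may be only part of what the source reports. "The series", "measured", "known", "first", "only" and "open" are said of these compounds alone.

For the measured compounds named here, the series so far holds two measured compounds. Compound 1 `CCCCCCCCCCCCCCNC(=O)[C@@H](NC(=O)c1ccco1)[C@@H](C)O` gives 190000 nM in a functional assay on A-431 cells (Homo sapiens) for cytotoxicity, read by MTT assay, with a stated time of 48 h; on this read-out lower numbers stand for stronger inhibition and higher numbers for weaker inhibition. Compound 2 `CCCCCCCCCCCCCCCCCCNC(=O)[C@@H](NC(=O)c1ccco1)[C@@H](C)O` gives 19900 nM in this assay. Going by the values given here, the only measured step is a 9.5-fold lower number from compound 1 to compound 2 (0.98 log units; beyond the scatter), reached through butyl in place of hydrogen on a saturated chain carbon, ten or more bonds along the chain from an amide-type nitrogen. Compound 2 therefore stands at the lowest of the two numbers, with compound 1 beyond the scatter above it.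

Compound 3 `C/C=C/C=C/C(=O)N[C@H](C(=O)NCCCCCCCCCCCCCCCCCC)[C@@H](C)O` keeps the chain of compound 2 and differs from it by penta-1,3-dien-1-yl in place of furan-2-yl on a carbonyl carbon. Among the compounds with values here, no measured step touches this part of the molecule; the step from compound 1 to compound 2 concerns the chain alone and offers no guidance for an exchange at the carbonyl carbon. Without precedent in the series, the expectation is a step within the scatter, a 1.0-fold higher number from compound 2 to compound 3 (0.00 log units; within the scatter), in either direction, carried with a wide range. Compound 3 is accordingly estimated at 20000 nM in this assay, with a range from 5000 nM to 80000 nM.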

Compound 3, half-maximal inhibitory concentration: 187000 nM
Compound 3: middle estimate off by 9.4-fold (0.97 log units), on the low side; measured number above the stated range.
By their numbers in this assay, from the lowest: compound 2; then compounds 3 and 1 (each within the scatter of the next).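

The carbonyl carbon is a position that responds in this assay: with the chain of compound 2 held fixed, penta-1,3-dien-1-yl in place of furan-2-yl gives a 9.4-fold higher number from compound 2 to compound 3 (0.97 log units; beyond the scatter) on this read-out. The series now holds one change that lowers the number, a 9.5-fold lower number from compound 1 to compound 2 (0.98 log units; beyond the scatter) at the chain, and one at the carbonyl carbon that raises it, so the chain is not the only part of these amides that matters for this read-out. On the chain of compound 2, furan-2-yl gives the lower number of the two groups, but the change swaps a five-membered aromatic ring holding one hydrogen-bond acceptor for an open chain with two double bonds, and nothing in hand explains the step or separates these differences.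

Still open, on these data alone, is whether the exchange at the carbonyl carbon gives a step of similar size and direction on the chain of compound 1, or on a longer chain. Also open, as far as these compounds go, is how a saturated pentyl group, a phenyl ring or a thiophene ring on the same carbonyl carbon would compare with furan-2-yl and penta-1,3-dien-1-yl.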